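The compounds below may be only part of what the source reports. "The series", "measured", "known", "first", "only" and "open" are said of these compounds alone.

The three measured compounds share one core and differ only in the group on the aromatic nitrogen. In a functional assay on A549 cells (Homo sapiens) for cytotoxicity, read by MTT assay, with a stated time of 24 h (on this read-out lower numbers stand for stronger inhibition and higher numbers for weaker inhibition), compound 1 `COc1ccc(/C=C\C(=O)O)c(OCc2cn(-c3ccccc3I)nn2)c1CC=C(C)C` gives 2200 nM. Compound 2 `COc1ccc(/C=C\C(=O)O)c(OCc2cn(-c3ccccc3C#N)nn2)c1CC=C(C)C` gives 38600 nM in this assay, and compound 3 `COc1ccc(/C=C\C(=O)O)c(OCc2cn(-c3nc4ccccc4s3)nn2)c1CC=C(C)C` gives 42100 nM in this assay. Compound 2 thus stands second highest of the three numbers: its nearest neighbour is compound 3, through a 1.1-fold higher number from compound 2 to compound 3 (0.04 log units; within the scatter), and its furthest is compound 1, through an 18-fold higher number from compound 1 to compound 2 (1.24 log units; beyond the scatter).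

The change from compound 2 to compound 4 `COc1ccc(/C=C\C(=O)O)c(OCc2cn(-c3ccc(C#N)cc3)nn2)c1CC=C(C)C` is 4-cyanophenyl in place of 2-cyanophenyl on an aromatic nitrogen. Among the compounds with values here, none of the measured steps keeps the same atoms and joins them differently: an 18-fold higher number from compound 1 to compound 2 (1.24 log units; beyond the scatter) exchanges one group for another, while a 19-fold higher number from compound 1 to compound 3 (1.28 log units; beyond the scatter) and a 1.1-fold higher number from compound 2 to compound 3 (0.04 log units; within the scatter) replace the whole group on the aromatic nitrogen. Within the data shown here, there is therefore no direct precedent for this step, and both large steps involve compound 1 rather than compound 2. The two steps that start from or end at compound 2 without touching the iodo group point in different directions, so the author expects no step beyond the scatter in this assay, namely a 1.1-fold lower number from compound 2 to compound 4 (0.04 log units; within the scatter). Compound 4 is accordingly estimated at 35000 nM, within a range from 12000 nM to 100000 nM.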

Compound 4, half-maximal inhibitory concentration: 42200 nM
Estimate against measurement, compound 4: 1.2-fold (0.08 log units) below; measured number inside the range.
By their numbers in this assay, from the lowest: compound 1; then compounds 2, 3 and 4 (each within the scatter of the next).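

Moving the nitrile from 2-cyanophenyl to 4-cyanophenyl keeps the same atoms and joins them differently, and in this assay this gives a 1.1-fold higher number from compound 2 to compound 4 (0.04 log units; within the scatter) with no change beyond the scatter, so for this pair the place of the nitrile on the phenyl ring does not separate the two compounds. Compound 4 also lies level with the benzothiazole compound, through a 1.0-fold higher number from compound 3 to compound 4 (0.00 log units; within the scatter) on the same read-out, whereas a 19-fold higher number from compound 1 to compound 4 (1.28 log units; beyond the scatter) is as large as the two steps from compound 1 already seen, so among these four compounds only compound 1, with its 2-iodophenyl group, stands apart from the others. Nothing given here bears on why the place of the nitrile leaves the number unmoved or why compound 1 differs from the rest.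

The compounds shown leave open whether the lower number of compound 1 belongs to the iodine itself or to its place on the ring, a question that a 4-iodophenyl group on the same core would address. They also leave open whether another atom or group in that place, such as a 2-bromophenyl or a 2-aminophenyl group, would stay with compound 1 or with compounds 2, 3 and 4.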